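Working notes: changing the aryl group on the carbonyl

The source may report more compounds than this note shows. Statements on the series, on what has been measured and on what is new or still open speak of the compounds shown alone.

Within the data shown here, in a functional assay on MCF7 cells (Homo sapiens) for inhibition, read by MTT assay (a higher number here means a weaker inhibitor, a lower number a stronger inhibitor), only two compounds have numbers so far. Compound 1 (`COc1cc2ncnc(Nc3ccc(NC(=O)c4ccc(C)cc4)cc3)c2cc1OC`) gives 19000 nM. Among the measured compounds shown here, compound 2 (`COc1cc2ncnc(Nc3ccc(NC(=O)c4cccc(I)c4)cc3)c2cc1OC`) gives 30000 nM, and its only neighbour on the scale is compound 1, so both are weak on this read-out and cannot be ordered.

Compound 3 (`COc1cc2ncnc(Nc3ccc(NC(=O)c4cc(F)ccc4Br)cc3)c2cc1OC`) keeps the shared core and the amide and differs from compound 2 in one place: 2-bromo-5-fluorophenyl in place of 3-iodophenyl on a carbonyl carbon. In words, this is 2-bromo-5-fluorophenyl in place of 3-iodophenyl on a carbonyl carbon.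

For the measured compounds named here, one measured step bears on this change, since it falls at the same place: a 1.6-fold higher number from compound 1 to compound 2 (0.20 log units; within the scatter). That exchange of 3-iodophenyl for 4-methylphenyl stays within the scatter. Going by the values given here, no measured compound carries a group resembling 2-bromo-5-fluorophenyl, so this single precedent is thin and the range is kept wide. No shift beyond the scatter is expected in this assay, and no direction can be argued.

The estimated change is a 1.2-fold lower number from compound 2 to compound 3 (0.08 log units; within the scatter). The estimate for compound 3 is 25000 nM, with an expected range from 10000 nM to 60000 nM.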

Compound 3, half-maximal inhibitory concentration: 26000 nM
Estimate against measurement, compound 3: 1.0-fold (0.02 log units) below; the range from low to high includes it.
By their numbers in this assay, from the lowest: compounds 1, 3 and 2 (each within the scatter of the next).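

In this assay, the exchange of 3-iodophenyl for 2-bromo-5-fluorophenyl on the carbonyl carbon gives a 1.2-fold lower number from compound 2 to compound 3 (0.06 log units; within the scatter), and the exchange of 4-methylphenyl for the same group gives a 1.4-fold higher number from compound 1 to compound 3 (0.14 log units; within the scatter). This position now takes a third aryl group, with fluorine and bromine where the earlier groups carry iodine or methyl, and all three compounds stay within the scatter of one another, so the two earlier compounds' lack of separation extends to a differently substituted phenyl ring. No independent evidence on this series bears on the result.

The compounds shown leave open whether a phenyl ring carrying a carboxylic acid or a dimethylamino group, or a longer alkyl chain in place of the aryl group on the carbonyl carbon, would move the number beyond the scatter. They also leave open whether a change to the amide or the shared core would bring the series out of this weak range.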